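The compounds below may be only part of what the source reports. "The series", "measured", "known", "first", "only" and "open" are said of these compounds alone.

Measured compounds:
- compound 1, `Cc1ccc(NC(=S)OCCc2ccccc2)cc1`, gives > 100000 nM in an ADME assay on MT4 cells (Homo sapiens) for cytotoxicity, read by MTT assay; on this read-out lower numbers stand for higher toxicity in this test and higher numbers for lower toxicity in this test; this is a limit of the assay, not a number.
- compound 2, `O=[N+]([O-])c1ccc(NC(=S)OCCc2ccccc2)cc1`, gives > 100000 nM in this assay; this too is a limit, not a number.

For the measured compounds named here, compound 2 therefore stands at the limit of this assay, and so does the only other measured compound. Going by the values given here, the single step between measured compounds, a step that the two limits leave unreadable from compound 1 to compound 2, cannot be read, since both ends sit at the limit; the evidence on this series is the limit of > 100000 nM in this assay, at which 2 of the 2 values shown sit.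

Compound 3, `O=[N+]([O-])c1ccc(NC(=S)OCCc2ccncc2)cc1`, is not yet measured. It differs from compound 2 as follows: pyridin-4-yl in place of phenyl on a saturated chain carbon, two bonds along the chain from an oxygen on an unsaturated carbon.

Among the compounds with values here, no measured step bears on this change, so there is no basis for expecting a step in this assay in either direction beyond the scatter; the only information is that both measured compounds sit at the limit. Compound 3 is therefore expected to sit at or near the same limit, with an estimated step of a number no higher from compound 2 to compound 3 (the limit leaves the size open). The estimate for compound 3 in this assay is 100000 nM, within a range from 40000 nM to 300000 nM, with a high chance that only a limit is reported.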

Compound 3, half-maximal cytotoxic concentration: > 100000 nM
Compound 3: only a limit was reported; the forecaster's own chance of this, stated with the estimate: 80%; the middle value lies on the limit itself.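

In this assay compound 3 gives > 100000 nM, which is a limit, not a number. No step can therefore be read from compound 2 to compound 3, and the series stands as before: the limit of > 100000 nM in this assay, at which 3 of the 3 values shown sit.

The compounds shown leave open where any of them would reach half-maximal cytotoxicity, and whether pyridin-4-yl in place of phenyl changes that value at all.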